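Two inactive tetracyclic chromones and a methoxy analogue

This account rests on a few compounds, and the source may have more. Where it says the series, first, only, none or still open, it means among the compounds named here.

Compound 1, `Cc1ccc2c(c1)C(C)(C)[C@H]1COc3ccc4c(=O)c(C)c(C)oc4c3[C@H]1N2`, reaches only the assay limit of > 100000 nM in a functional assay on MDA-MB-231 cells (Homo sapiens) for antiproliferative activity, read by MTT assay; on this read-out lower numbers stand for stronger inhibition and higher numbers for weaker inhibition.
Compound 2, `Cc1oc2c3c(ccc2c(=O)c1C)OC[C@H]1[C@@H]3Nc2ccccc2C1(C)C`, likewise reaches only the limit of > 100000 nM in this assay.

Compound 1 and compound 2 differ by a hydrogen in place of a methyl on an aromatic carbon, and the step from one to the other, a step that the two limits leave unreadable from compound 1 to compound 2, cannot be read because both values are limits. Compound 2 therefore stands at the limit of this assay, as does compound 1; the limit of > 100000 nM in this assay, at which 2 of the 2 values shown sit, is all the measured data show. Compound 3, `COc1ccc2c(c1)C(C)(C)[C@H]1COc3ccc4c(=O)c(C)c(C)oc4c3[C@H]1N2`, has not yet been measured in this assay. It differs from compound 2 by methoxy in place of hydrogen on an aromatic carbon. For the measured compounds named here, the only measured step, the one from compound 1 to compound 2, is unreadable, so nothing among the measured compounds sets the size or direction of a step from a hydrogen to a methoxy at this position. Compound 3 is expected to remain near the limit, with an estimated step of a number no higher from compound 2 to compound 3 (the limit leaves the size open) and an estimated value of 100000 nM, between 30000 nM and 300000 nM, though the assay may again report only a limit.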

Compound 3, half-maximal inhibitory concentration: > 100000 nM
Compound 3 ended at the assay's limit; the forecaster's own chance of this, stated with the estimate: 70%; the middle value sits exactly at the limit.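

For the compounds shown here, no step among compound 1, compound 2 and compound 3 can be read in this assay, since all three values are limits and not numbers: the limit of > 100000 nM in this assay, at which 3 of the 3 values shown sit. The compounds shown leave open whether hydrogen, methyl or methoxy at this aromatic carbon makes any difference to antiproliferative activity, as the true potency of each compound remains unknown.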